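The compounds below may be only part of what the source reports. "The series", "measured", "known", "first", "only" and "open" are said of these compounds alone.

Two numbers are shown in a functional assay on UACC-62 cells (Homo sapiens) for inhibition, read by sulforhodamine B assay, with a stated time of 48 h, tested at 10 uM; on this read-out higher numbers stand for more inhibition at the one concentration tested (going by the name of the read-out) and lower numbers for less inhibition: compound 2 `c1csc(-c2cn3ccnc3c(-c3ccc4ncn(C5CCCCC5)c4c3)n2)c1` gives 24.8%, and compound 1 `Brc1cn2ccnc2c(-c2ccc3ncn(C4CCCCC4)c3c2)n1` gives 19.8%, with a number 5 percentage points higher from compound 1 to compound 2 (within the scatter). Compound 3 `FC(F)(F)c1cccc(-c2cn3ccnc3c(-c3ccc4ncn(C5CCCCC5)c4c3)n2)c1` carries 3-(trifluoromethyl)phenyl in place of thiophen-2-yl on an aromatic carbon. Within the data shown here, the one measured step, thiophen-2-yl in place of bromo on the same aromatic carbon, bears on this only loosely; it stayed within the scatter, and no measured pair sets one aryl group against another. The step is therefore expected to be a number 0.2 percentage points higher from compound 2 to compound 3 (within the scatter), with no direction beyond the scatter. Compound 3 is estimated at 25%, with a range from 8% to 45%.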

Compound 3, a percentage reported as inhibition, at one concentration (the size of the read-out at that concentration, not a potency): 4.33%
For compound 3 the middle estimate is 20.7 percentage points above the measured one, outside the stated range (below it).
By their numbers in this assay, from the lowest: compound 3; then compounds 1 and 2 (each within the scatter of the next).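

In this assay, 3-(trifluoromethyl)phenyl on this aromatic carbon gives a number 20.5 percentage points lower from compound 2 to compound 3 (beyond the scatter), and a number 15.5 percentage points lower from compound 1 to compound 3 (beyond the scatter). The position therefore responds to the group it carries, which the step from bromo to thiophen-2-yl, within the scatter, did not show. No measurement at hand accounts for the lower number.

The compounds shown leave open whether that number goes with the six-membered aromatic ring or with its trifluoromethyl. Plain phenyl would bear on this, and an amine such as morpholine on the same carbon would test a non-aryl group there.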